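The compounds below may be only part of what the source reports. "The series", "measured", "known", "first", "only" and "open" are said of these compounds alone.

Three compounds from one series were tested in a functional assay on A549 cells (Homo sapiens) for inhibition, read by MTT assay, with a stated time of 24 h; a lower number here means a stronger inhibitor of growth, a higher number a weaker inhibitor of growth. Compound 1 `COc1ccccc1C(=O)n1c(-c2cn(C)c3ccccc23)nc2ccccc21` gives 12300 nM in this assay. Compound 2 `COc1cccc(C(=O)n2c(-c3cn(C)c4ccccc34)nc3ccccc32)c1` differs from it by 3-methoxyphenyl in place of 2-methoxyphenyl on a carbonyl carbon, and in this assay compound 2 gives 10200 nM, a step of a 1.2-fold lower number from compound 1 to compound 2 (0.08 log units; within the scatter). Compound 3 `COc1ccc2c(c1)c(-c1nc3ccccc3n1C(=O)c1ccccc1OC)cn2C` differs from compound 1 by methoxy in place of hydrogen on an aromatic carbon; in this assay compound 3 gives 11900 nM, a step of a 1.0-fold lower number from compound 1 to compound 3 (0.01 log units; within the scatter). All three numbers lie within the scatter of one another, so no order among them can be read from these data.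

Compound 4 `COc1cccc(C(=O)n2c(-c3cn(C)c4ccc(OC)cc34)nc3ccccc32)c1` has not yet been measured. It stands to compound 3 as compound 2 stands to compound 1: the difference is 3-methoxyphenyl in place of 2-methoxyphenyl on a carbonyl carbon, the same change at the same place, while the cores of the two pairs differ in the way already described for compound 1 and compound 3. Since the earlier instance of this change gave a 1.2-fold lower number from compound 1 to compound 2 (0.08 log units; within the scatter), a number close to that of compound 3 is expected, with an estimated step of a 1.2-fold lower number from compound 3 to compound 4 (0.08 log units; within the scatter). Compound 4 is therefore expected to give about 10000 nM in this assay, most likely between 5000 nM and 20000 nM.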

Compound 4, concentration for 50% growth inhibition: 4600 nM
Compound 4: middle estimate off by 2.2-fold (0.34 log units), on the high side, outside the stated range (below it).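

In this assay, 3-methoxyphenyl in place of 2-methoxyphenyl on a carbonyl carbon gives a 2.6-fold lower number from compound 3 to compound 4 (0.41 log units; beyond the scatter), yet this step cannot be told apart from the earlier instance of the same change: the same change on two cores in this assay, a 1.2-fold lower number (0.08 log units; within the scatter) from compound 1 to compound 2 and a 2.6-fold lower number (0.41 log units; beyond the scatter) from compound 3 to compound 4, 2.1-fold (0.33 log units) apart, within the scatter of two such steps. Methoxy in place of hydrogen on an aromatic carbon gives a 2.2-fold lower number from compound 2 to compound 4 (0.35 log units; beyond the scatter), and this step likewise cannot be told apart from its earlier instance: the same change on two cores in this assay, a 1.0-fold lower number (0.01 log units; within the scatter) from compound 1 to compound 3 and a 2.2-fold lower number (0.35 log units; beyond the scatter) from compound 2 to compound 4, 2.1-fold (0.33 log units) apart, within the scatter of two such steps. Going by these compounds alone, the data therefore give no sign that either change depends on the core it is carried to, but they do not show that its size is the same on both cores, as each comparison rests on only two steps and both of the steps beyond the scatter end at compound 4.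

As far as these compounds go, it remains open whether these steps would hold with an ethoxy group, a hydroxyl group or a fluorine in place of methoxy on the phenyl group. The same is true of an amine or a carboxylic acid at that place.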